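Compound 3: 3-chlorophenyl in place of furan-2-yl

The source may report more compounds than this note shows. Statements on the series, on what has been measured and on what is new or still open speak of the compounds shown alone.

In a functional assay on HeLa cells (Homo sapiens) for cytotoxicity, read by ELISA, with a stated time of 4 days (a higher number here means a weaker inhibitor, a lower number a stronger inhibitor), compound 1 `Cc1ccsc1-c1cc(-c2ccc(Cl)o2)cc(-c2ccco2)n1` gives 22200 nM. In this assay compound 2 `Clc1ccc(-c2cc(-c3ccco3)nc(-c3ccc(Cl)s3)c2)o1` gives > 50000 nM, which is a limit and not a number. Among the measured compounds shown here, the only measured step, an at least 2.2-fold higher number from compound 1 to compound 2 (0.35 log units; beyond the scatter), exchanges 3-methylthiophen-2-yl for 5-chlorothiophen-2-yl and lies beyond the scatter.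

Compound 3 `Clc1cccc(-c2cc(-c3ccc(Cl)o3)cc(-c3ccc(Cl)s3)n2)c1` keeps the 5-chlorofuran-2-yl and 5-chlorothiophen-2-yl groups of compound 2 but carries 3-chlorophenyl in place of furan-2-yl, next to the ring nitrogen (3-chlorophenyl in place of furan-2-yl on an aromatic carbon). For the measured compounds named here, no measured step involves furan-2-yl, so the step above bears on this change only indirectly and gives its likely size, not a firm direction. A modest move towards a lower number is expected, an at least 2.0-fold lower number from compound 2 to compound 3 (0.30 log units; that floor lies within the scatter), although another limit reading remains possible. For compound 3 the estimated value is 25000 nM, with an expected range of 6000 nM to 60000 nM.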

Compound 3, half-maximal inhibitory concentration: 25200 nM
For compound 3 the middle estimate is 1.0-fold (0.00 log units) below the measured one, and the stated range covers the measured number.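

In this assay, the position next to the ring nitrogen now has a step of its own, with 3-chlorophenyl in place of furan-2-yl: an at least 1.9-fold lower number from compound 2 to compound 3 (0.29 log units; that floor lies within the scatter). Compound 3 gives a number rather than a limit while carrying both the 5-chlorofuran-2-yl and 5-chlorothiophen-2-yl groups, so these two groups together do not fix the reading at the limit. The true size of the step stays open because compound 2 stands at a limit and not at a number: the limit of > 50000 nM in this assay, at which 1 of the 3 values shown sits.

The compounds shown do not tell whether the chlorine or the six-membered ring of carbon only carries the step, a question that an unsubstituted phenyl would address. Nor do they show how an amine or a carboxylic acid on that ring would read in this assay.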